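Carboxy on the saturated ring of compound 3

This account rests on a few compounds, and the source may have more. Where it says the series, first, only, none or still open, it means among the compounds named here.

In a functional assay on Caco-2 cells (Homo sapiens) for inhibition, read by MTT assay, with a stated time of 48 h, tested at 10 uM (a lower number here means less inhibition of growth, a higher number more inhibition of growth at the concentration tested), compound 3 (`Cc1cc(=O)c2c(O)c(CN3CCCC3)c(O)c([C@H]3CCN(C)C[C@H]3O)c2o1`) gives 22%. Compound 1 (`Cc1cc(=O)c2c(O)cc(OCc3ccc(Br)cc3)c([C@H]3CCN(C)C[C@H]3O)c2o1`) gives 13%. Compound 3 and compound 1 lie within the scatter of each other. Compound 2 (`Cc1cc(=O)c2c(O)cc(OCc3ccccc3Br)c([C@H]3CCN(C)C[C@H]3O)c2o1`) gives 35%. Compound 3 lies lower than compound 2, and that gap is beyond the scatter. Compound 4 (`Cc1cc(=O)c2c(O)c(CN3CCCC3C(=O)O)c(O)c([C@H]3CCN(C)C[C@H]3O)c2o1`) carries 2-carboxypyrrolidin-1-yl in place of pyrrolidin-1-yl: carboxy in place of hydrogen on a saturated ring carbon. Going by the values given here, the only measured step, a number 22 percentage points higher from compound 1 to compound 2 (beyond the scatter), is 2-bromophenyl in place of 4-bromophenyl, a different change, so it bears only on the size a single change can reach. Among the compounds with values here, no measured compound carries carboxy, so no direction is supported. The expected step is a number 4 percentage points lower from compound 3 to compound 4 (within the scatter), none beyond the scatter. For compound 4 the estimate is 18%, with an expected range of 5% to 35%.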

Compound 4, percent growth inhibition at one concentration: 30%
Compound 4: middle estimate off by 12 percentage points, on the low side, within the range that was stated.
By their numbers in this assay, from the lowest: compounds 1, 3, 4 and 2 (each within the scatter of the next, the first and the last beyond it).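

In this assay, carboxy in place of hydrogen on a saturated ring carbon, next to the ring nitrogen, gives a number 8 percentage points higher from compound 3 to compound 4 (within the scatter). Going by these compounds alone, this is the first reading at this position of the five-membered ring: it takes carboxy, with its hydrogen-bond donor and acceptor, without a step beyond the scatter. No supporting measurement bears on this result. Open, going by these compounds, is whether a methyl ester, a primary amide or an aminomethyl group on the same ring carbon would also stay within the scatter of compound 3.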